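The compounds below may be only part of what the source reports. "The series", "measured", "known", "first", "only" and "open" are said of these compounds alone.

Measured compounds in an assay on cells for antagonist activity at transient receptor potential cation channel subfamily V member 1 (Homo sapiens), read by FLIPR and calcium flux, with a stated time of 6 min; a higher number here means a weaker inhibitor, a lower number a stronger inhibitor:
compound 1, `CCCCN(C)c1cc(C(C)(C)C)ccc1CNC(=O)C(C)c1ccc(NS(C)(=O)=O)c(F)c1`, 1 nM;
compound 2, `CC(C(=O)NCc1ccc(C(C)(C)C)cc1N1CCCC1)c1ccc(NS(C)(=O)=O)c(F)c1`, 8.1 nM;
compound 3, `CC(C)CCOc1cc(C(C)(C)C)ccc1CNC(=O)C(C)c1ccc(NS(C)(=O)=O)c(F)c1`, 0.6 nM.

Compound 3 gives the lowest of the three numbers in this assay. Its nearest neighbour is compound 1, and the step of a 1.7-fold lower number from compound 1 to compound 3 (0.22 log units; within the scatter) lies within the scatter, so the two cannot be ordered. Compound 2 stands furthest away: the step of a 14-fold lower number from compound 2 to compound 3 (1.13 log units; beyond the scatter) is large and well beyond the scatter.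

Compound 4, `CC(C(=O)NCc1ccc(C(C)(C)C)cc1SC1CCCCC1)c1ccc(NS(C)(=O)=O)c(F)c1`, has not been measured. It differs from compound 3 in one place: cyclohexylsulfanyl in place of isopentyloxy on an aromatic carbon. The group that enters carries a six-membered non-aromatic ring of carbon only, and the one that leaves is a chain with no ring. Among the measured steps, the two that involve a ring bear on this change. Replacing the open-chain butyl(methyl)amino by the ring-bearing pyrrolidin-1-yl gave an 8.1-fold higher number from compound 1 to compound 2 (0.91 log units; beyond the scatter), a modest rise, and the reverse direction from the ring to the open chain isopentyloxy gave a 14-fold lower number from compound 2 to compound 3 (1.13 log units; beyond the scatter). On that basis compound 4 is expected to show a higher number than compound 3, a modest step of about a 2.5-fold higher number from compound 3 to compound 4 (0.40 log units; beyond the scatter). Compound 4 is thus estimated at 1.5 nM in this assay, within a range from 0.4 nM to 6 nM.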

Compound 4, inhibition constant: 7.4 nM
The estimate for compound 4 lay 4.9-fold (0.69 log units) below the measured number, and the stated range ends below it.
By their numbers in this assay, from the lowest: compounds 3 and 1 (each within the scatter of the next); then compounds 4 and 2 (each within the scatter of the next).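

In this assay, the cost of a ring at this position, on an aromatic carbon ortho to a large group, is no longer confined to a ring joined through nitrogen: cyclohexylsulfanyl in place of isopentyloxy gave a 12-fold higher number from compound 3 to compound 4 (1.09 log units; beyond the scatter), and in place of butyl(methyl)amino it gave a 7.4-fold higher number from compound 1 to compound 4 (0.87 log units; beyond the scatter). Against the other ring-bearing group, cyclohexylsulfanyl in place of pyrrolidin-1-yl gave a 1.1-fold lower number from compound 2 to compound 4 (0.04 log units; within the scatter), so these two compounds cannot be ordered, and among the four compounds both ring-bearing groups now give higher numbers than both open-chain groups, with no compound going against this. Nothing available here accounts for this pattern.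

The compounds shown leave open whether the ring or the sulfur carries the step from isopentyloxy to cyclohexylsulfanyl, since both change together; cyclohexyloxy and isopentylsulfanyl would pull the two apart. They also leave open whether the pattern would extend to other ring-bearing groups at this position, such as piperidin-1-yl or cyclopentylsulfanyl.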